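Benzamide sulfamates: the step from compound 3 to compound 4

A few compounds are considered here, and "the series" means these few. Any claim that something is new, unique, unknown or untested is made for them only; others in the source may bear on it.

Measured so far:
compound 1 `CN(C)CCN(CCN(C)C)c1ccc(C(=O)N2CCc3ccc(OS(N)(=O)=O)cc3C2)cc1`: 3.8%
compound 2 `NS(=O)(=O)Oc1ccc2c(c1)CN(C(=O)c1cccc(N3CCC(N4CCCCC4)CC3)c1)CC2`: 0%
compound 3 `CCN(Cc1ccccc1)c1cccc(C(=O)N2CCc3ccc(OS(N)(=O)=O)cc3C2)c1`: 17.3%

In an assay on HEK293 cells for inhibition of Steryl-sulfatase (Homo sapiens), tested at 0.1 uM (on this read-out higher numbers stand for a stronger effect at the one concentration tested and lower numbers for a weaker effect), compound 3 gives the highest of the three numbers. The nearest is compound 1, whose value lies lower by a margin beyond the scatter; compound 2 lies furthest, also beyond the scatter. Compound 4 `NS(=O)(=O)Oc1ccc2c(c1)CN(C(=O)c1cccc(N(Cc3ccccc3)Cc3ccco3)c1)CC2` differs from compound 3 in one place: furan-2-yl in place of methyl on a saturated chain carbon bound to a nitrogen on an aromatic ring. Among the compounds with values here, no pair of measured compounds shows what such a change does here, so any expectation rests on compound 3 alone. The step is expected to be small and slightly upward, not clearly beyond the scatter: a number 2.7 percentage points higher from compound 3 to compound 4 (within the scatter). Compound 4 is therefore estimated at 20%, with a range from 5% to 40%.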

Compound 4, a percentage reported as inhibition, at one concentration (the size of the read-out at that concentration, not a potency): 27.5%
Compound 4: the middle estimate sits 7.5 percentage points below what was measured; the range from low to high includes it.
By their numbers in this assay, from the lowest: compounds 2 and 1 (each within the scatter of the next); then compound 3; then compound 4.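

In this assay, furan-2-yl in place of methyl on a saturated chain carbon bound to a nitrogen on an aromatic ring gives a number 10.2 percentage points higher from compound 3 to compound 4 (beyond the scatter). This single-place step shows that this position accepts a five-membered aromatic ring without loss, and that the read-out responds to the group placed there. No available measurement bears on why the number rises.

On these data alone, it remains open whether the ring oxygen or the ring itself carries the step. A thiophen-2-yl ring, a phenyl ring or a longer chain such as propyl at the same place would separate these readings.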